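A few compounds are considered here, and "the series" means these few. Any claim that something is new, unique, unknown or untested is made for them only; others in the source may bear on it.

Three measured compounds share one core and differ only in the group carried on an aromatic carbon. In an assay on cells for displacement of a labelled ligand from prostaglandin E2 receptor EP4 subtype (Homo sapiens), read by scintillation counting (on this read-out higher numbers stand for weaker inhibition and lower numbers for stronger inhibition), compound 1 `Cc1oc(C(=O)NS(=O)(=O)c2ccccc2)cc1COc1ccc(-c2ccccc2)cc1` gives 25 nM. Compound 2 `COc1ccc(-c2ccc(OCc3cc(C(=O)NS(=O)(=O)c4ccccc4)oc3C)cc2)nc1` gives 22 nM, and compound 3 `Cc1oc(C(=O)NS(=O)(=O)c2ccccc2)cc1COc1ccc(-c2ccc(OC(F)F)cc2)cc1` gives 1.3 nM. On these numbers compound 2 stands with compound 1 at the upper end and well above compound 3: the step from compound 1 to compound 2 was a 1.1-fold lower number from compound 1 to compound 2 (0.06 log units; within the scatter), while the step from compound 2 to compound 3 was a 17-fold lower number from compound 2 to compound 3 (1.23 log units; beyond the scatter). Compound 4 `COc1ccc(-c2ccc(OCc3cc(C(=O)O)oc3C)cc2)nc1` differs from compound 2 by hydroxy in place of (phenylsulfonyl)amino on a carbonyl carbon. Going by the values given here, no measured step touches this carbonyl carbon; every step concerns the distal aromatic group, so none bears on the change. Compound 4 is therefore estimated, with wide bounds, at 60 nM (10 nM to 400 nM). That estimate means an expected step of a 2.7-fold higher number from compound 2 to compound 4 (0.44 log units; beyond the scatter).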

Compound 4, inhibition constant: 1300 nM
For compound 4 the middle estimate is 22-fold (1.34 log units) below the measured one, outside the stated range (above it).
By their numbers in this assay, from the lowest: compound 3; then compounds 2 and 1 (each within the scatter of the next); then compound 4.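

In this assay, hydroxy in place of (phenylsulfonyl)amino on the carbonyl carbon gives a 59-fold higher number from compound 2 to compound 4 (1.77 log units; beyond the scatter). Going by these compounds alone, the earlier steps concerned only the distal aromatic group, so this is the first sign that the number is also highly sensitive to the group on this carbonyl carbon. No supporting data on why the number rises are available here.

From the compounds shown here alone, it remains open whether the step depends on the whole (phenylsulfonyl)amino group or only part of it, which methylsulfonylamino or a plain amino group on this carbon could test. Going by these compounds, it is also open whether hydroxy would give a similar step on compound 3, with its 4-(difluoromethoxy)phenyl group.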